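Replacing an Amine Chain with a Hexyl Chain

The source may report more compounds than this note shows. Statements on the series, on what has been measured and on what is new or still open speak of the compounds shown alone.

In a functional assay on the whole organism with Mus musculus as the target, in the rotarod test (a higher number here means that more compound is needed for the effect, a lower number that less compound is needed), compound 1 (`CC(C)NCC(=O)NCC(=O)N(C)c1ccc(Cl)cc1C(=O)c1ccccc1Cl`) stands at 13 mg/kg and compound 2 (`NCC(=O)NCC(=O)Nc1ccc([N+](=O)[O-])cc1C(=O)c1ccccc1`) at 24.8 mg/kg within the usual scatter of each other. Compound 3 (`NC(C(=O)NCC(=O)Nc1ccc(Cl)cc1C(=O)c1ccccc1)c1ccccc1`) has > 100 mg/kg as a limit, not a number. Compound 4 (`CCCCCCC(=O)NCC(=O)N(C)c1ccc(Cl)cc1C(=O)c1ccccc1Cl`) carries pentyl in place of isopropylamino on a saturated chain carbon bound to a carbonyl carbon. Starting from compound 1 at 13 mg/kg with no measured swap of this kind as a guide, a move toward a higher number in this assay is expected, though its size is uncertain. The expected change is a 3.1-fold higher number from compound 1 to compound 4 (0.49 log units; beyond the scatter) and remains a rough estimate. Compound 4 is expected at 40 mg/kg (estimated range 10 mg/kg to 160 mg/kg).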

Compound 4, dose for half-maximal effect: 70 mg/kg
Compound 4: middle estimate off by 1.8-fold (0.24 log units), on the low side; measured number inside the range.
By their numbers in this assay, from the lowest: compounds 1 and 2 (each within the scatter of the next); then compound 4. At a limit, above all of these: compound 3.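

In this assay, putting pentyl in place of isopropylamino on a saturated chain carbon bound to a carbonyl carbon gives a 5.4-fold higher number from compound 1 to compound 4 (0.73 log units; beyond the scatter), so more compound is needed for the effect. This place in the molecule therefore responds to the change, yet compound 4, with no amine in this chain, still gives a measured number rather than a limit. Nothing measured here explains the shift. Still open, on these data alone, is how a longer chain, an ether or a carboxylic acid at this place would compare.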